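A few compounds are considered here, and "the series" means these few. Any claim that something is new, unique, unknown or untested is made for them only; others in the source may bear on it.

Measured in a functional assay on SW480 cells (Homo sapiens) for antiproliferative activity, read by MTT assay, with a stated time of 48 h; a higher number here means a weaker inhibitor, a lower number a stronger inhibitor:
Compound 1 `CCCCCCCCCC(CCOS(C)(=O)=O)n1cnc2c(Cl)ncnc21`: 5390 nM
Compound 2 `CCCCCCCCCC(CCN=[N+]=[N-])n1cnc2c(Cl)ncnc21`: 1200 nM

Compound 2 holds the lower of these two numbers, which makes it the stronger inhibitor so far. Compound 3 `CCCCCCCCCC(CCCl)n1cnc2c(Cl)ncnc21` has chloro in place of azido on a saturated chain carbon, three bonds along the chain from an aromatic nitrogen. Among the compounds with values here, only one measured step bears on this place: a 4.5-fold lower number from compound 1 to compound 2 (0.65 log units; beyond the scatter). Within the data shown here, that modest step shows that changing this group can move the number, but no chloro compound has been measured. A similarly modest rise in this assay is expected, estimated as a 1.7-fold higher number from compound 2 to compound 3 (0.22 log units; within the scatter). For compound 3 the estimate is 2000 nM, with an expected range of 700 nM to 6000 nM.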

Compound 3, half-maximal inhibitory concentration: 7180 nM
Beside the measured number, compound 3's estimate is 3.6-fold (0.56 log units) below it; measured number above the stated range.
By their numbers in this assay, from the lowest: compound 2; then compounds 1 and 3 (each within the scatter of the next).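

In this assay, putting chloro in place of azido gives a 6.0-fold higher number from compound 2 to compound 3 (0.78 log units; beyond the scatter), so not every small group at this saturated chain carbon matches azido. Chloro and (methylsulfonyl)oxy cannot be told apart, with a 1.3-fold higher number from compound 1 to compound 3 (0.12 log units; within the scatter), which leaves azido alone among the three with the lower number. Nothing measured here explains why azido stands apart. From the compounds shown here alone, whether an amine, a nitrile or a hydroxyl group on this chain carbon would match azido, or go lower still, remains open.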